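Furan-2-yl in Place of Benzyl on the Shared Core

A few compounds are considered here, and "the series" means these few. Any claim that something is new, unique, unknown or untested is made for them only; others in the source may bear on it.

Compound 1 `Nc1nc(Cc2ccccc2)nc2cn(-c3ccccc3O)nc12` gives 52 nM in an assay on CHO cells for displacement of a labelled ligand from adenosine receptor A1 (Homo sapiens), read by scintillation counting, with a stated time of 120 min (on this read-out higher numbers stand for weaker inhibition and lower numbers for stronger inhibition), the highest of the three numbers recorded there, though within the scatter of both neighbours. Compound 2 `COc1ccccc1-n1cc2nc(CCCc3ccccc3)nc(N)c2n1` gives 49 nM in this assay, and compound 3 `Cc1ccc(-c2nc(N)c3nn(-c4ccccc4)cc3n2)o1` gives 42 nM, so no ordering among the three can be claimed. Compound 4 `Nc1nc(-c2ccco2)nc2cn(-c3ccccc3O)nc12` differs from compound 1 by furan-2-yl in place of benzyl on an aromatic carbon, on an aromatic carbon of the shared core, between two ring nitrogen atoms. Among the measured compounds shown here, no measured pair isolates this change. Compound 3 carries a related five-membered ring at that carbon and gives 42 nM, which offers mild encouragement. Compound 4 is therefore expected to give about 25 nM, within 6 nM to 100 nM, a modest step toward stronger inhibition of a 2.1-fold lower number from compound 1 to compound 4 (0.32 log units; beyond the scatter) that may not clear the scatter.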

Compound 4, inhibition constant: 372 nM
For compound 4 the middle estimate is 15-fold (1.17 log units) below the measured one; measured number outside the range, above it.
By their numbers in this assay, from the lowest: compounds 3, 2 and 1 (each within the scatter of the next); then compound 4.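

Among the compounds shown here, this is the first pair that isolates a change at this aromatic carbon, between two ring nitrogen atoms, and in this assay furan-2-yl in place of benzyl gives a 7.2-fold higher number from compound 1 to compound 4 (0.85 log units; beyond the scatter). On the shared core, then, the position is not indifferent to the group it carries, and benzyl goes with the stronger inhibition of the two. Nothing measured here accounts for the step.

As far as these compounds go, whether an amine or a directly attached phenyl at this carbon would stand nearer compound 1 or compound 4 stays open. So does whether the same change gives a similar step with a methoxy group in place of the hydroxyl group.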